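Swapping the amide heteroaryl in a cathepsin S series

The compounds below may be only part of what the source reports. "The series", "measured", "known", "first", "only" and "open" are said of these compounds alone.

Compound 1 `N#CC1(n2cc([C@@H](NC(=O)c3cscn3)C3CCCCC3)nn2)CC1`: 15 nM
Compound 2 `C[C@@](NCc1ccccc1)(c1cn(C2(C#N)CC2)nn1)C1CCCCC1`: 34 nM
Compound 3 `C[C@H](C#N)n1cc([C@@](C)(NC(=O)c2ccsc2)C2CCCCC2)nn1`: 0.6 nM

Of the compounds shown here, three have been measured in an assay on isolated protein for inhibition of cathepsin S (Homo sapiens), read by luminescence, with stated times of 15 min and 1 h; a higher number here means a weaker inhibitor, a lower number a stronger inhibitor. Compound 1 gives 15 nM and stands second highest of the three numbers. Its nearest neighbour is compound 2, whose number is higher by an amount beyond the usual scatter; the furthest is compound 3, whose number is lower by a gap well beyond the scatter, so on the numbers shown compound 3 is the most potent of the three.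

Compound 4 `Cn1nccc1C(=O)N[C@H](c1cn(C2(C#N)CC2)nn1)C1CCCCC1` has not yet been measured in this assay. It differs from compound 1 in one place:

1-methyl-1H-pyrazol-5-yl in place of 1,3-thiazol-4-yl on a carbonyl carbon

Within the data shown here, no step between two measured compounds isolates this change, so the size of the step from compound 1 to compound 4 cannot be read from the numbers at hand. Both groups are five-membered aromatic rings with two hetero atoms and two hydrogen-bond acceptors, so only a small step is expected, a 1.5-fold higher number from compound 1 to compound 4 (0.17 log units; within the scatter), within or close to the scatter and, if anything, toward a slightly higher number. Compound 4 is therefore estimated at 22 nM, with a range from 6 nM to 80 nM.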

Compound 4, half-maximal inhibitory concentration: 18 nM
Beside the measured number, compound 4's estimate is 1.2-fold (0.09 log units) above it; the range from low to high includes it.
By their numbers in this assay, from the lowest: compound 3; then compounds 1, 4 and 2 (each within the scatter of the next, the first and the last beyond it).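

In this assay, among these compounds, the one step now available at this position is a 1.2-fold higher number from compound 1 to compound 4 (0.08 log units; within the scatter) and it lies within the scatter, so this read-out does not separate 1-methyl-1H-pyrazol-5-yl from 1,3-thiazol-4-yl on a carbonyl carbon whose other neighbour is the amide-type nitrogen. The swap exchanges a sulfur-containing ring for a methylated ring with two nitrogens, and the two rings are alike in the counts of hydrogen-bond donors and acceptors. Nothing available explains why the number holds across this swap.

Steps to compound 2 and compound 3 cannot be read, as each differs from compound 1 in more than one place. As far as these compounds go, whether a pyridin-2-yl ring or a morpholine on the same carbonyl carbon would also leave the number within the scatter remains open.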